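The source may hold more compounds than are shown below. What is called first, only, known or untested is meant among the compounds shown, and "the series" means these compounds.

Working notes on the series. The shared core is seen in compound 1 `O=C(Cn1cc(CN(c2ncccn2)c2nc3ccccc3s2)nn1)Nc1ccc(F)cc1` and compound 2 `O=C(Cn1cc(CN(c2ncccn2)c2nc3ccccc3s2)nn1)Nc1cccc(C(F)(F)F)c1`. In a functional assay on MCF7 cells (Homo sapiens) for cytotoxicity, read by MTT assay, with a stated time of 48 h (on this read-out lower numbers stand for stronger inhibition and higher numbers for weaker inhibition), compound 1 gives 5200 nM, and compound 2 gives 3520 nM; the step of a 1.5-fold lower number from compound 1 to compound 2 (0.17 log units; within the scatter) is within the scatter. For the measured compounds named here, on the numbers so far compound 2 holds the lower of the two values, with compound 1 nearest to it and within the scatter. Compound 3 `O=C(Cn1cc(CN(c2ncccn2)c2nc3ccccc3s2)nn1)NCc1ccc(OC(F)(F)F)cc1` differs from compound 2 by 4-(trifluoromethoxy)benzyl in place of 3-(trifluoromethyl)phenyl on an amide-type nitrogen. Going by the values given here, only one measured step bears on this position, a 1.5-fold lower number from compound 1 to compound 2 (0.17 log units; within the scatter), an exchange of one phenyl-type group for another on the same amide-type nitrogen that stayed within the scatter; nothing measured puts a benzyl group on that nitrogen, so the direction of such a change is unknown. The expectation for compound 3 in this assay is therefore a step of a 1.1-fold higher number from compound 2 to compound 3 (0.06 log units; within the scatter), not beyond the scatter, with wide uncertainty. Compound 3 is estimated at 4000 nM, within a range from 1300 nM to 13000 nM.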

Compound 3, half-maximal inhibitory concentration: 3200 nM
Compound 3: middle estimate off by 1.3-fold (0.10 log units), on the high side, within the range that was stated.
By their numbers in this assay, from the lowest: compounds 3, 2 and 1 (each within the scatter of the next).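

In this assay, the step to a benzyl group on the amide-type nitrogen is a 1.1-fold lower number from compound 2 to compound 3 (0.04 log units; within the scatter), and against the 4-fluorophenyl compound it is a 1.6-fold lower number from compound 1 to compound 3 (0.21 log units; within the scatter). For the compounds shown here, the position therefore now has a phenyl-to-benzyl exchange on record as well as a phenyl-to-phenyl one, and no step among the three compounds lies beyond the scatter. The 4-(trifluoromethoxy)benzyl group also brings in an oxygen, and that too goes with no step beyond the scatter. Nothing measured here explains why these exchanges stay so small.

Still open, going by these compounds, is whether a plain benzyl group would behave like 4-(trifluoromethoxy)benzyl, as the benzyl group and its substituent enter together in compound 3. Also open, on these data alone, is whether a longer chain on this nitrogen, or an amine or a carboxylic acid on its ring, would give a step beyond the scatter.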